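The source may report more compounds than this note shows. Statements on the series, on what has been measured and on what is new or still open speak of the compounds shown alone.

In a functional assay on MDA-MB-231 cells (Homo sapiens) for antiproliferative activity, with a stated time of 5 days (on this read-out higher numbers stand for weaker inhibition and lower numbers for stronger inhibition), compound 1 (`Cc1ccc(-n2nc(-c3ccc4ccccc4c3)nc2N2C(=O)COC23C=CC(=O)C=C3)cc1`) gives 30 nM and compound 2 (`Cc1ccccc1-n1nc(-c2cccc3ccccc23)nc1N1C(=O)COC12C=CC(=O)C=C2`) gives 120 nM. Compound 2 therefore stands at the higher of the two numbers, on the weaker-inhibition side, and the gap lies beyond the usual scatter. Compound 3 (`Cc1ccc(-n2nc(-c3cccc4ccccc34)nc2N2C(=O)COC23C=CC(=O)C=C3)cc1`) keeps the naphthalen-1-yl group of compound 2 and has 4-methylphenyl in place of 2-methylphenyl on an aromatic nitrogen of the five-membered aromatic ring: 4-methylphenyl in place of 2-methylphenyl on an aromatic nitrogen. Going by the values given here, no measured pair isolates this change. Compound 1, at 30 nM, carries the same 4-methylphenyl as compound 3 but differs elsewhere, so it offers only a loose pointer towards a lower number. A moderate move towards stronger inhibition is expected, the estimated 2.0-fold lower number from compound 2 to compound 3 (0.30 log units; within the scatter). For compound 3 the expected value in this assay is 60 nM, with an estimated range of 20 nM to 170 nM.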

Compound 3, half-maximal inhibitory concentration: 40 nM
For compound 3 the middle estimate is 1.5-fold (0.18 log units) above the measured one, and the stated range covers the measured number.
By their numbers in this assay, from the lowest: compounds 1 and 3 (each within the scatter of the next); then compound 2.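

In this assay, going by these compounds alone, with naphthalen-1-yl held constant, 4-methylphenyl in place of 2-methylphenyl on an aromatic nitrogen gives a 3.0-fold lower number from compound 2 to compound 3 (0.48 log units; beyond the scatter) and is the first measured isolation of this change, so this position responds to where the methyl sits on the phenyl ring. Within the data shown here, with 4-methylphenyl held constant, naphthalen-1-yl in place of naphthalen-2-yl on an aromatic carbon gives a 1.3-fold higher number from compound 1 to compound 3 (0.12 log units; within the scatter), so of the two changes separating compound 1 and compound 2, only the one on the aromatic nitrogen has a step beyond the scatter here. No measured data bear on the reason for this difference.

As far as these compounds go, whether 2-methylphenyl gives the same step alongside naphthalen-2-yl remains open. Also open, from the compounds shown here alone, is how a carboxylic acid or an amine on the phenyl ring would read at this aromatic nitrogen.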